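This account rests on a few compounds, and the source may have more. Where it says the series, first, only, none or still open, it means among the compounds named here.

Working notes on the series

Three close analogues carry the same core and differ only in the benzyl group on the ether oxygen. Compound 1 `N#Cc1cccc(COc2cc(O)c3c(=O)c(O)c(-c4ccccc4)oc3c2)c1` gives 72000 nM in an ADME assay on Huh-5-2 cells (Homo sapiens) for cytotoxicity, read by WST assay, with a stated time of 3 days; on this read-out higher numbers stand for lower toxicity in this test and lower numbers for higher toxicity in this test. Compound 2 `O=c1c(O)c(-c2ccccc2)oc2cc(OCc3cccc([N+](=O)[O-])c3)cc(O)c12` gives 76000 nM in this assay, and compound 3 `N#Cc1ccc(COc2cc(O)c3c(=O)c(O)c(-c4ccccc4)oc3c2)cc1` gives 94000 nM in this assay.

The measured steps are all small. The change nitro in place of cyano on an aromatic carbon gives a 1.1-fold higher number from compound 1 to compound 2 (0.02 log units; within the scatter). The change 4-cyanophenyl in place of 3-cyanophenyl on a saturated chain carbon bound to an oxygen on an aromatic ring gives a 1.3-fold higher number from compound 1 to compound 3 (0.12 log units; within the scatter). The remaining pair gives a 1.2-fold higher number from compound 2 to compound 3 (0.09 log units; within the scatter). None of the three compounds can be set apart from the others on this read-out.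

Compound 4 `O=c1c(O)c(-c2ccccc2)oc2cc(OCc3ccc([N+](=O)[O-])cc3)cc(O)c12` is not yet measured in this assay. It differs from compound 3 by nitro in place of cyano on an aromatic carbon. Among the measured compounds shown here, this is the same kind of change as the one from compound 1 to compound 2, but not the same: in the measured pair the group sits meta to a large group, whereas in compound 4 it sits para to a large group. The cores of the two pairs differ as 4-cyanophenyl in place of 3-cyanophenyl on a saturated chain carbon bound to an oxygen on an aromatic ring.

For the measured compounds named here, the only precedent for swapping cyano for nitro is the step of a 1.1-fold higher number from compound 1 to compound 2 (0.02 log units; within the scatter), which lay within the scatter. Going by the values given here, on that basis compound 4 is expected to show a step of about a 1.1-fold higher number from compound 3 to compound 4 (0.03 log units; within the scatter), again within the scatter, because the one measured instance of this change gave a 1.1-fold higher number from compound 1 to compound 2 (0.02 log units; within the scatter). The estimate for compound 4 in this assay is 100000 nM, with a range from 50000 nM to 200000 nM.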

Compound 4, half-maximal cytotoxic concentration: 93000 nM
Compound 4: the middle estimate sits 1.1-fold (0.03 log units) above what was measured; the measured number falls inside the stated range.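

Nitro in place of cyano carries from one core to the other with no readable shift in this assay, the new instance being a 1.0-fold lower number from compound 3 to compound 4 (0.00 log units; within the scatter), and the two instances agree: the same change on two cores in this assay, a 1.1-fold higher number (0.02 log units; within the scatter) from compound 1 to compound 2 and a 1.0-fold lower number (0.00 log units; within the scatter) from compound 3 to compound 4, 1.1-fold (0.03 log units) apart, within the scatter of two such steps. The other two new steps, a 1.2-fold higher number from compound 2 to compound 4 (0.09 log units; within the scatter) and a 1.3-fold higher number from compound 1 to compound 4 (0.11 log units; within the scatter), are also within the scatter, so none of the four compounds can be set apart on this read-out. Among the compounds shown here, this shows only that the swap leaves the read-out flat on these two cores; with no step beyond the scatter, it does not show whether a change of real size would carry across in the same way, and it gives no reason for the agreement.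

The compounds shown leave open whether the read-out stays this flat with a benzyl group that carries neither cyano nor nitro, for example one bearing an amine or a carboxylic acid. They also leave open what a longer chain between the ether oxygen and the aromatic ring would do, and whether any change to the shared core itself would give a step beyond the scatter.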